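The source may report more compounds than this note shows. Statements on the series, on what has been measured and on what is new or still open speak of the compounds shown alone.

Series notes. Compound 1 `COc1cc(/C=C/C(=O)CC(=O)/C=C/c2ccc(OCC=C(C)C)c(OC)c2)ccc1OCC=C(C)C` carries a methoxy and a (3-methylbut-2-en-1-yl)oxy group on each end of the shared core. In an ADME assay on HEK293 cells (Homo sapiens) for cytotoxicity, read by resazurin assay, with a stated time of 16 h (a higher number here means that more compound is needed for the effect, a lower number that less compound is needed), compound 1 gives only a limit of the assay, > 1000000 nM. Compound 2 `COc1cc(/C=C/C(=O)CC(=O)/C=C/c2ccc(OCC=C(C)C)cc2)ccc1OCC=C(C)C` lacks one methoxy. In this assay compound 2 likewise gives only a limit, > 500000 nM. The change between them is hydrogen in place of methoxy on an aromatic carbon; the step that the two limits leave unreadable from compound 1 to compound 2 cannot be sized, since the limit of > 1000000 nM in this assay, at which 1 of the 3 values shown sits, and the limit of > 500000 nM in this assay, at which 1 of the 3 values shown sits, are both limits and not numbers.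

For the measured compounds named here, compound 3 `COc1cc(/C=C/C(=O)CC(=O)/C=C/c2ccc(OC(=O)c3ccccc3)c(OC)c2)ccc1O` is the only member with a number rather than a limit: in this assay compound 3 gives 94000 nM. The difference between the core of compound 3 and the core of compound 1 is not broken down here.

Compound 4 `COc1cc(/C=C/C(=O)CC(=O)/C=C/c2ccc(O)cc2)ccc1OC(=O)c1ccccc1`, not yet measured, differs from compound 3 by hydrogen in place of methoxy on an aromatic carbon. This is the same kind of change as from compound 1 to compound 2, but the place differs: there the carbon sat ortho to a (3-methylbut-2-en-1-yl)oxy group, here it sits ortho to a hydroxy group. Going by the values given here, the one measured instance of the change is unreadable, so no direction of effect can be taken from it. In this assay compound 4 is expected to lie close to compound 3, at 100000 nM, within 40000 nM to 300000 nM, which means an expected step of a 1.1-fold higher number from compound 3 to compound 4 (0.03 log units; within the scatter) within the usual scatter.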

Compound 4, half-maximal effective concentration: 370000 nM
The estimate for compound 4 lay 3.7-fold (0.57 log units) below the measured number, and the stated range ends below it.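

On the core of compound 3, hydrogen in place of methoxy on an aromatic carbon, ortho to a hydroxy group, gives in this assay a 3.9-fold higher number from compound 3 to compound 4 (0.60 log units; beyond the scatter), which is the one readable size for this change in the series. The same change on the core of compound 1 leaves a step that cannot be read, as compound 1 and compound 2 both stand only as limits of the assay and not as numbers. The series therefore shows the change raising the number on one core, but it does not show whether that rise carries over to another core, in direction or in size, and a single readable pair sets no rule.

The compounds shown leave open how the change would read on a core carrying (3-methylbut-2-en-1-yl)oxy groups if both members gave numbers rather than limits, and whether a second core with a hydroxy group at this place would repeat the step. They also leave open how any group other than methoxy or hydrogen would read at this aromatic carbon in this assay, such as an amine, a carboxylic acid or a longer chain.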